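This account rests on a few compounds, and the source may have more. Where it says the series, first, only, none or still open, it means among the compounds named here.

Measured compounds:
- compound 1, `CCOC(=O)C1=Cc2ccccc2OC1(OCc1cn(-c2ccc(F)cc2)nn1)C(F)(F)F`
- compound 2, `CCOC(=O)C1=Cc2ccccc2OC1(OCc1cn(-c2ccccc2)nn1)C(F)(F)F`
- compound 3, `O=C(O)C1=Cc2ccccc2OC1(OCc1cc(-c2ccc(F)cc2F)no1)C(F)(F)F`

In a functional assay on A549 cells (Homo sapiens) for inhibition, read by MTT assay, with a stated time of 24 h (a higher number here means a weaker inhibitor, a lower number a stronger inhibitor), compound 1 gives 7300 nM. For compound 2 only a limit of the assay is recorded, > 150000 nM. For compound 3 likewise only a limit is recorded, > 150000 nM. The step of an at least 20-fold higher number from compound 1 to compound 2 (1.31 log units; beyond the scatter) rests on the change (hydrogen in place of fluoro on an aromatic carbon). How the core of compound 3 differs from that of compound 1 is not broken down here.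

Compound 4, `O=C(O)C1=Cc2ccccc2OC1(OCc1cc(-c2ccc(F)cc2)no1)C(F)(F)F`, awaits measurement in this assay. It differs from compound 3 by hydrogen in place of fluoro on an aromatic carbon. This is the same kind of change as from compound 1 to compound 2, not the same: there the fluoro sat para to a large group, here it sits ortho to a large group and meta to a fluoro group.

Among the compounds with values here, the only measured instance of this kind of change gave a large rise, an at least 20-fold higher number from compound 1 to compound 2 (1.31 log units; beyond the scatter), and compound 3 already stands at the limit of > 150000 nM in this assay, at which 2 of the 3 values shown sit. Compound 4 is therefore expected to remain at that limit, with an expected step that the limit leaves unreadable from compound 3 to compound 4. The estimate for compound 4 is 250000 nM, between 100000 nM and 600000 nM.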

Compound 4, half-maximal inhibitory concentration: > 150000 nM
Compound 4: no number, only a limit (the forecaster's own chance of this, stated with the estimate: 85%); the middle value is on the limit's open side.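

In this assay compound 4 gives > 150000 nM, a limit and not a number. Compound 3 also stands at a limit, and no step between compound 3 and compound 4 can be read: the limit of > 150000 nM in this assay, at which 3 of the 4 values shown sit.

The compounds shown leave open whether hydrogen in place of fluoro changes inhibition at all on the core of compound 3.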